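The source may report more compounds than this note shows. Statements on the series, on what has been measured and on what is new or still open speak of the compounds shown alone.

Three compounds sharing one core, all carrying a substituted benzyl group on the oxygen of the oxime, have been measured in a functional assay on MGC-803 cells (Homo sapiens) for cytotoxicity, read by MTT assay, with a stated time of 2 days; a lower number here means a stronger inhibitor, a higher number a weaker inhibitor. Compound 1 `c1ccc(CO/N=C2/C(c3c[nH]c4ccccc34)=Nc3ccccc32)cc1` bears an unsubstituted phenyl ring and gives 15400 nM. Compound 2 `Fc1ccc(CO/N=C2/C(c3c[nH]c4ccccc34)=Nc3ccccc32)cc1` carries a fluoro on that ring and gives 33000 nM. Compound 3 `FC(F)(F)c1ccc(CO/N=C2/C(c3c[nH]c4ccccc34)=Nc3ccccc32)cc1` carries a trifluoromethyl instead and gives 30600 nM. Among these three, compound 3 sits second highest, with compound 2 nearest and compound 1 furthest; both of those gaps lie within the usual scatter, so the three numbers cannot be set in a firm order. The measured steps are small throughout: a 2.1-fold higher number from compound 1 to compound 2 (0.33 log units; beyond the scatter), a 2.0-fold higher number from compound 1 to compound 3 (0.30 log units; within the scatter) and a 1.1-fold lower number from compound 2 to compound 3 (0.03 log units; within the scatter).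

Compound 4 `Fc1ccc(CO/N=C2/C(c3c[nH]c4ccccc34)=Nc3ccccc32)c(Cl)c1` has not yet been measured. Relative to compound 3 the change is 2-chloro-4-fluorophenyl in place of 4-(trifluoromethyl)phenyl on a saturated chain carbon bound to an oxygen on an unsaturated carbon. Going by the values given here, the fluoro kept in compound 4 recalls compound 2, whose value and that of compound 3 are within the scatter of each other, so the added chloro has no measured precedent here. With every measured step on this ring being modest or within the scatter, the expectation for compound 4 is no change beyond the scatter, a 1.0-fold lower number from compound 3 to compound 4 (0.01 log units; within the scatter). Compound 4 is therefore estimated at 30000 nM, within a range from 12000 nM to 75000 nM.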

Compound 4, half-maximal inhibitory concentration: 18500 nM
For compound 4 the middle estimate is 1.6-fold (0.21 log units) above the measured one; low and high end bracket the measured number.
By their numbers in this assay, from the lowest: compounds 1, 4, 3 and 2 (each within the scatter of the next, the first and the last beyond it).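

In this assay, chloro in place of hydrogen on the ring of compound 2 gives a 1.8-fold lower number from compound 2 to compound 4 (0.25 log units; within the scatter) and so puts a second group on that ring without a step beyond the usual scatter. Set against the other rings at this place, the 2-chloro-4-fluorophenyl group gives a 1.7-fold lower number from compound 3 to compound 4 (0.22 log units; within the scatter) when it replaces 4-(trifluoromethyl)phenyl and a 1.2-fold higher number from compound 1 to compound 4 (0.08 log units; within the scatter) when it replaces phenyl. Going by these compounds alone, compound 1 and compound 2 are the only pair whose gap lies beyond the scatter, and compound 4 lies within the scatter of both, so this place accepts a ring with two groups, but the new value gives no firm order among the four compounds.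

The compounds shown carry only phenyl rings, bare or with fluoro, chloro or trifluoromethyl, at this place, so what an amine, a carboxylic acid or a longer chain on that ring would do to the number stays open. Why these four numbers lie so close together also stays open, as nothing available gives a reason for it.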